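Chloro-to-methyl swap on the pendant aryl ring

A few compounds are considered here, and "the series" means these few. Any claim that something is new, unique, unknown or untested is made for them only; others in the source may bear on it.

Of the compounds shown here, three have been measured in a functional assay on B16-F10 cells (Mus musculus) for antiproliferative activity, read by MTT assay, with a stated time of 48 h; on this read-out lower numbers stand for stronger inhibition and higher numbers for weaker inhibition. Compound 1 `O=C(Nc1nnc(-c2ccc(Cl)cc2)s1)c1ccccc1O` gives 1150 nM. Compound 2 `Cc1ccc(-c2nnc(NC(=O)c3ccccc3O)s2)cc1`, which carries methyl in place of chloro on an aromatic carbon, gives 1970 nM; the step of a 1.7-fold higher number from compound 1 to compound 2 (0.23 log units; within the scatter) is small. Compound 3 `O=C(Nc1nnc(-c2ccccc2)s1)c1ccc(Cl)cc1` gives 4650 nM, the highest of the three numbers, and the difference between its core and the core of compound 1 is not broken down here.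

Compound 4 `Cc1ccc(C(=O)Nc2nnc(-c3ccccc3)s2)cc1` is not yet measured. It differs from compound 3 by the same change seen between compound 1 and compound 2, methyl in place of chloro on an aromatic carbon, at a place described in the same words, para to a large group. On the earlier pair this change produced only a 1.7-fold higher number from compound 1 to compound 2 (0.23 log units; within the scatter), a step within the scatter, so the expectation for compound 4 in this assay is a step of about a 1.4-fold higher number from compound 3 to compound 4 (0.15 log units; within the scatter) from compound 3, resting on that single precedent and nothing else. Compound 4 is therefore estimated at 6500 nM, with a likely range from 3000 nM to 15000 nM.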

Compound 4, half-maximal inhibitory concentration: 2760 nM
Compound 4: middle estimate off by 2.4-fold (0.37 log units), on the high side; the whole stated range lies above it.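

In this assay, methyl in place of chloro gives a 1.7-fold lower number from compound 3 to compound 4 (0.23 log units; within the scatter), opposite in direction to the step on the core of compound 1, and the two steps do not agree: the same change on two cores in this assay, a 1.7-fold higher number (0.23 log units; within the scatter) from compound 1 to compound 2 and a 1.7-fold lower number (0.23 log units; within the scatter) from compound 3 to compound 4, 2.9-fold (0.46 log units) apart, beyond the scatter of two such steps

Each step taken alone is within the scatter, so neither core by itself shows a real effect of the swap; it is only the gap between the two steps that shows a step read on one core cannot simply be carried to the other. Two pairs do not show which of the differences between the two cores lies behind that gap, nor whether a third core would follow either step.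

The compounds shown leave open how a methoxy group, an amine or a carboxylic acid in place of chloro would read on either core. Also open, from the compounds shown here alone, is whether a longer chain, such as propyl, in place of methyl would keep the two cores apart in the same way.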